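Nitro in Place of Bromo: Expected Cytotoxicity for Compound 3

A few compounds are considered here, and "the series" means these few. Any claim that something is new, unique, unknown or untested is made for them only; others in the source may bear on it.

Measured so far:
compound 1 `COC(=O)c1cc(-c2cccc(NC(=O)c3ccc(/C=C/C(=O)c4ccc(Br)cc4)cc3)c2)on1` — > 20 ug/mL
compound 2 `CCCOc1ccc(C(=O)/C=C/c2ccc(C(=O)O)cc2)cc1` — < 10 ug/mL

Of the compounds shown here, two have been read in an ADME assay on Vero cells (Chlorocebus sabaeus) for cytotoxicity, read by MTT assay, with a stated time of 72 h; on this read-out higher numbers stand for lower toxicity in this test and lower numbers for higher toxicity in this test. For compound 1 the value is only a limit of this assay, > 20 ug/mL, so compound 1 sits at the limit of > 20 ug/mL in this assay, at which 1 of the 2 values shown sits. For compound 2 the value is likewise only a limit, < 10 ug/mL, at the limit of < 10 ug/mL in this assay, at which 1 of the 2 values shown sits. Compound 3 `COC(=O)c1cc(-c2cccc(NC(=O)c3ccc(/C=C/C(=O)c4ccc([N+](=O)[O-])cc4)cc3)c2)on1` keeps the core of compound 1 and differs by nitro in place of bromo on an aromatic carbon. Going by the values given here, no measured pair shares this change, so the expected step that the limit leaves unreadable from compound 1 to compound 3 is none beyond the usual scatter. Compound 3 is therefore estimated to give 25 ug/mL, expected between 10 ug/mL and 60 ug/mL.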

Compound 3, half-maximal cytotoxic concentration: > 20 ug/mL
Compound 3 was reported as a limit; the forecaster's own chance of this, stated with the estimate: 60%; the middle value is on the limit's open side.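

In this assay, compound 1 and compound 3 are both reported only as limits, so no step can be read between them. The compounds shown leave open whether nitro in place of bromo shifts cytotoxicity at all.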